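The source may report more compounds than this note shows. Statements on the series, on what has been measured and on what is new or still open speak of the compounds shown alone.

Measured compounds in a functional assay (aorta) with Rattus norvegicus as the target; a lower number here means a stronger inhibitor, a higher number a weaker inhibitor:
Compound 1 `CCOC(=O)CN(c1ccc(F)cc1)[C@H]1c2cc(C#N)ccc2OC(C)(C)[C@@H]1O` gives > 30000 nM, which is a limit of the assay.
Compound 2 `CCOC(=O)CN(c1nc(C)cs1)[C@H]1c2cc(C#N)ccc2OC(C)(C)[C@@H]1O` gives 84000 nM.
Compound 3 `CCOC(=O)C(=O)N(c1ccc(F)cc1)[C@H]1c2cc(C#N)ccc2OC(C)(C)[C@@H]1O` gives 43000 nM.

Compound 3 holds the lowest of the two numbers in this assay, yet its nearest neighbour, compound 2, lies within the scatter, so no order between them can be read. The steps a step that the limit leaves unreadable from compound 1 to compound 3 and a step that the limit leaves unreadable from compound 1 to compound 2 stay unreadable because of the limit of > 30000 nM in this assay, at which 1 of the 3 values shown sits. Compound 4 `CC1(C)Oc2ccc(C#N)cc2[C@H](N(Cc2ncc[nH]2)c2ccc(F)cc2)[C@H]1O` differs from compound 3 by (1H-imidazol-2-yl)methyl in place of (ethoxycarbonyl)carbonyl on a nitrogen on an aromatic ring. Among the compounds with values here, no measured step touches that change, so the only guide is the weak and flat range of the three values. Compound 4 is therefore expected to stay near compound 3, with the step of a 1.1-fold lower number from compound 3 to compound 4 (0.03 log units; within the scatter) estimated as nothing beyond the scatter, giving an estimate of 40000 nM with a range from 10000 nM to 150000 nM.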

Compound 4, half-maximal inhibitory concentration: > 30000 nM
Compound 4: only a limit was reported; the forecaster's own chance of this, stated with the estimate: 35%; the middle value does not contradict the limit.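

No new step can be read, neither from compound 3 to compound 4 nor from compound 1 to compound 4, because of a limit: the limit of > 30000 nM in this assay, at which 2 of the 4 values shown sit.
In this assay the compounds shown leave open whether changing the group on the nitrogen shifts the number at all.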